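Trimethoxyphenyl pyrazole enones: measured values and next step

A few compounds are considered here, and "the series" means these few. Any claim that something is new, unique, unknown or untested is made for them only; others in the source may bear on it.

Measured so far:
compound 1 `COc1ccc2c(c1)C/C(=C\c1cc(-c3cc(OC)c(OC)c(OC)c3)n[nH]1)C2=O` — 2100 nM
compound 2 `COc1cc(-c2cc(/C=C/C(=O)c3ccc(Cl)c(Cl)c3)[nH]n2)cc(OC)c1OC` — 3200 nM

In a functional assay on MCF7 cells (Homo sapiens) for inhibition, read by MTT assay, with a stated time of 48 h (a higher number here means a weaker inhibitor, a lower number a stronger inhibitor), compound 2 gives 3200 nM, the higher of the two numbers, yet the gap to compound 1 lies within the scatter, so the two are not separated. Compound 3 `COc1ccc(C(=O)/C=C/c2cc(-c3cc(OC)c(OC)c(OC)c3)n[nH]2)cc1` differs from compound 2 by one exchange: 4-methoxyphenyl in place of 3,4-dichlorophenyl on a carbonyl carbon. Within the data shown here, no measured pair shows this exchange, so its effect is unknown. The expectation is a step in this assay of a 1.3-fold higher number from compound 2 to compound 3 (0.10 log units; within the scatter), not clearly beyond the scatter, and compound 3 is estimated at 4000 nM (range 1500 nM to 12000 nM).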

Compound 3, half-maximal inhibitory concentration: 810 nM
Estimate against measurement, compound 3: 4.9-fold (0.69 log units) above, and the stated range ends above it.
By their numbers in this assay, from the lowest: compound 3; then compounds 1 and 2 (each within the scatter of the next).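

On a carbonyl carbon, the choice of aryl group matters: in this assay 4-methoxyphenyl in place of 3,4-dichlorophenyl gives a 4.0-fold lower number from compound 2 to compound 3 (0.60 log units; beyond the scatter) and this is the only step on hand, so it is the first change in the series shown to lie beyond the scatter. The entering group carries 1 hydrogen-bond acceptor and the leaving group 0, with 8 heavy atoms in each. No supporting data explain the size of this step.

A single exchange does not separate gaining the methoxy group from losing the two chlorines. Still open, going by these compounds, is how an amine, a carboxylic acid or a longer alkoxy chain on that phenyl ring would compare.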